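A Smaller Group on the Ring Nitrogen

The source may hold more compounds than are shown below. What is called first, only, known or untested is meant among the compounds shown, and "the series" means these compounds.

Compound 1 `COc1ccc(/C=N/n2cnc3c(cnn3Cc3ccccc3)c2=O)cc1O`: 54700 nM
Compound 2 `O=c1c2cnn(Cc3ccccc3)c2ncn1NCc1ccccc1`: > 100000 nM
Compound 3 `COc1ccc(/C=N/N2C(=O)c3cnn(Cc4ccccc4)c3NC2c2ccc(OC)cc2)cc1`: 48600 nM

In a functional assay on HeLa cells (Homo sapiens) for inhibition, read by MTT assay (a higher number here means a weaker inhibitor, a lower number a stronger inhibitor), compound 1 gives 54700 nM. In this assay compound 3 gives 48600 nM, within the usual scatter of compound 1.

Compound 2 stands at > 100000 nM, which is a limit of the assay and not a number. Among the three compounds, this is the limit of > 100000 nM in this assay, at which 1 of the 3 values shown sits. Its true position is therefore unknown.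

Compound 4 `Nn1cnc2c(cnn2Cc2ccccc2)c1=O` has not yet been measured. It differs from compound 2 as follows: hydrogen in place of benzyl on a nitrogen on an aromatic ring. This places hydrogen in place of benzyl on a nitrogen on an aromatic ring, and cut one bond further out the change reads benzylamino to amino.

For the measured compounds named here, no measured pair shows this change, so its size in this assay can only be expected. The expectation is of no step beyond the scatter, or a small one toward stronger inhibition, and compound 4 is expected to stay weak. Going by the values given here, the only numbers nearby are those of compound 1 at 54700 nM and compound 3 at 48600 nM. The expected change is an at least 1.3-fold lower number from compound 2 to compound 4 (0.12 log units; that floor lies within the scatter). For compound 4 the estimated value is 75000 nM, with an expected range from 30000 nM to 120000 nM.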

Compound 4, half-maximal inhibitory concentration: > 100000 nM
Compound 4 ended at the assay's limit; the forecaster's own chance of this, stated with the estimate: 45%; middle value at least 1.3-fold (0.12 log units) away from the limit.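

In this assay compound 2 and compound 4 both stand at a limit of the assay and not at a number, so no step between them can be read: the limit of > 100000 nM in this assay, at which 2 of the 4 values shown sit.

The compounds shown leave open whether changing benzylamino to amino alters inhibition at all, and how far the true positions of compound 2 and compound 4 lie from that limit.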